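Replacing 2,6-dimethylphenyl with thiophen-2-yl

A few compounds are considered here, and "the series" means these few. Any claim that something is new, unique, unknown or untested is made for them only; others in the source may bear on it.

Two compounds have been measured so far in a functional assay on A549 cells (Homo sapiens) for cytotoxicity (a higher number here means that more compound is needed for the effect, a lower number that less compound is needed), and are shown here:
- compound 1 `COC1=C(C)C(=O)/C(=C(O)/C=C/c2ccc(O)cc2)C(=O)C1(C)C` gives 3.1 ug/mL in this test
- compound 2 `COC1=C(C)C(=O)/C(=C(O)/C=C/c2c(C)cccc2C)C(=O)C1(C)C` gives 8.3 ug/mL in this test

Compound 2 holds the higher of the two numbers, so more of it is needed for the effect. Among the measured compounds shown here, its only neighbour is compound 1, and the gap is a 2.7-fold higher number from compound 1 to compound 2 (0.43 log units; beyond the scatter) in this assay as measured.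

Compound 3 `COC1=C(C)C(=O)/C(=C(O)/C=C/c2cccs2)C(=O)C1(C)C` has not yet been measured. It keeps the shared core and differs from compound 2 at one place (thiophen-2-yl in place of 2,6-dimethylphenyl on a double-bonded chain carbon bound to a double-bonded chain carbon).

For the measured compounds named here, only one measured step bears on this change, and it swapped a group at the same place. That step was a 2.7-fold higher number from compound 1 to compound 2 (0.43 log units; beyond the scatter) and it was modest. It ended on 2,6-dimethylphenyl, the group that compound 3 gives up. Going by the values given here, no measured compound carries thiophen-2-yl, so the direction is only a cautious guess, leaning towards a lower number.

The expected step is a 2.1-fold lower number from compound 2 to compound 3 (0.32 log units; beyond the scatter) and it should be modest in size. Compound 3 is estimated at 4 ug/mL (expected range 1.8 ug/mL to 9 ug/mL).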

Compound 3, concentration for half-maximal effect: 4.5 ug/mL
For compound 3 the middle estimate is 1.1-fold (0.05 log units) below the measured one; the measured number falls inside the stated range.
By their numbers in this assay, from the lowest: compounds 1, 3 and 2 (each within the scatter of the next, the first and the last beyond it).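

In this assay, thiophen-2-yl, a five-membered aromatic ring with one hetero atom, takes the place of 2,6-dimethylphenyl (a 1.8-fold lower number from compound 2 to compound 3 (0.27 log units; within the scatter)) and of 4-hydroxyphenyl (a 1.5-fold higher number from compound 1 to compound 3 (0.16 log units; within the scatter)), and both steps stay within the scatter. This position therefore accepts a ring of a different size containing sulfur without a readable shift from either earlier compound, although those two compounds are separated by a step beyond the scatter; compound 3 cannot be placed closer to one than to the other. No measured information on any property of these groups is available to explain this result.

The compounds shown leave open how a furan-2-yl ring, with oxygen in place of the sulfur, or a saturated cyclohexyl ring would read on this double-bonded chain carbon. Going by these compounds, how a plain phenyl group would read is also open, and with it how much of the earlier step (a 2.7-fold higher number from compound 1 to compound 2 (0.43 log units; beyond the scatter)) belongs to the hydroxyl group and how much to the two methyl groups.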